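The source may hold more compounds than are shown below. What is called first, only, known or untested is meant among the compounds shown, and "the series" means these compounds.

Of the compounds shown here, two sharing one core have been measured so far. In a physicochemical assay for solubility, read by HPLC, using the shake flask method, in phosphate buffer, with a stated time of 20 h, at pH 6.5 (a lower number here means a less soluble compound, a higher number a more soluble compound), compound 1 (`CN1CCN(C2CCN(c3nccc4[nH]c(-c5cc(F)cc(F)c5)nc34)CC2)CC1`) gives 200000 nM. Compound 2 (`CN1CCN(CC2CCN(c3nccc4[nH]c(-c5ccc(F)c(Cl)c5)nc34)CC2)CC1`) gives 155000 nM, and the two numbers lie within the scatter of each other, so neither stands apart.

Compound 3 (`CN1CCN(CC2CCN(c3nccc4[nH]c(-c5cccc(C(=O)N(C)C)c5)nc34)CC2)CC1`) keeps everything in compound 2 except one group, on an aromatic carbon of a five-membered aromatic ring with 2 nitrogen, between two ring nitrogen atoms: 3-(dimethylcarbamoyl)phenyl in place of 3-chloro-4-fluorophenyl on an aromatic carbon. Here 3-(dimethylcarbamoyl)phenyl comes in place of 3-chloro-4-fluorophenyl. Among the measured compounds shown here, no measured pair shows this change on its own, so the data offer no direct precedent for it.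

The expectation rests on compound 1 at 200000 nM and compound 2 at 155000 nM, whose structures differ in more than one place and whose values still sit within the scatter of each other. The expected step, a 1.3-fold higher number from compound 2 to compound 3 (0.11 log units; within the scatter), is therefore small, and no change beyond the scatter is expected in this assay. For compound 3 the estimated value is 200000 nM, with an expected range from 90000 nM to 450000 nM.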

Compound 3, solubility: 180000 nM
Compound 3: the middle estimate sits 1.1-fold (0.05 log units) above what was measured; low and high end bracket the measured number.
By their numbers in this assay, from the lowest: compounds 2, 3 and 1 (each within the scatter of the next).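

In this assay, putting 3-(dimethylcarbamoyl)phenyl in place of 3-chloro-4-fluorophenyl on an aromatic carbon of the five-membered aromatic ring, between two ring nitrogen atoms, gives a 1.2-fold higher number from compound 2 to compound 3 (0.06 log units; within the scatter). This is the first step shown that differs in one place only, so the change at this position can now be read on its own rather than across compounds that differ in more than one place. The entering group has 11 heavy atoms against 8 and 1 hydrogen-bond acceptor against 0, yet the read-out stays within the scatter, and no measurement shown accounts for this result.

The compounds shown leave open whether this position would stay within the scatter with a carboxylic acid or a primary amine on the phenyl ring in place of the dimethylcarbamoyl group, since both groups present here carry no net charge. They also leave open what a single change elsewhere on the shared core would do, such as a longer chain in the part that carries the methylpiperazine.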